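Adding a second methyl to the anilide ring of compound 3

The source may report more compounds than this note shows. Statements on the series, on what has been measured and on what is new or still open speak of the compounds shown alone.

Measured so far in a functional assay on CCRF-CEM cells (Homo sapiens) for cytotoxicity; a lower number here means a stronger inhibitor, a higher number a weaker inhibitor:
compound 1 `O=C(/C=C/C(=O)N1C/C(=C\c2ccccc2)C(=O)/C(=C/c2ccccc2)C1)Nc1ccc(Cl)c(Cl)c1` gives 350 nM
compound 2 `Cc1cccc(C)c1NC(=O)/C=C/C(=O)N1C/C(=C\c2ccccc2)C(=O)/C(=C/c2ccccc2)C1` gives 7400 nM
compound 3 `Cc1ccc(NC(=O)/C=C/C(=O)N2C/C(=C\c3ccccc3)C(=O)/C(=C/c3ccccc3)C2)cc1` gives 1100 nM

Compound 3 stands second highest of the three, a step of a 3.1-fold higher number from compound 1 to compound 3 (0.50 log units; beyond the scatter) away from compound 1 and a 6.7-fold lower number from compound 2 to compound 3 (0.83 log units; beyond the scatter) from compound 2. Compound 4 `Cc1ccc(NC(=O)/C=C/C(=O)N2C/C(=C\c3ccccc3)C(=O)/C(=C/c3ccccc3)C2)cc1C` differs from compound 3 only by methyl in place of hydrogen on an aromatic carbon. Within the data shown here, no measured step adds a single methyl; the steps of a 3.1-fold higher number from compound 1 to compound 3 (0.50 log units; beyond the scatter) and a 6.7-fold lower number from compound 2 to compound 3 (0.83 log units; beyond the scatter) show that the pattern of substituents on this ring moves this assay by modest amounts in either direction. A small step, likely toward a lower number, is therefore expected, a 1.6-fold lower number from compound 3 to compound 4 (0.20 log units; within the scatter). Compound 4 is estimated at 700 nM, within 300 nM to 2000 nM.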

Compound 4, half-maximal inhibitory concentration: 7100 nM
Estimate against measurement, compound 4: 10-fold (1.01 log units) below; measured number above the stated range.
By their numbers in this assay, from the lowest: compound 1; then compound 3; then compounds 4 and 2 (each within the scatter of the next).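

In this assay, methyl in place of hydrogen on this aromatic carbon, ortho to a methyl group, proves a real penalty (a 6.5-fold higher number from compound 3 to compound 4 (0.81 log units; beyond the scatter)). The two dimethylphenyl compounds sit level (a 1.0-fold lower number from compound 2 to compound 4 (0.02 log units; within the scatter)), while the same substitution pattern as in compound 4 with chlorine instead of methyl keeps far stronger activity (a 20-fold higher number from compound 1 to compound 4 (1.31 log units; beyond the scatter)), so at this position the identity of the group matters and not only the substitution pattern. Nothing available explains this rise. On these data alone, whether a single chlorine, an ethyl or a methoxy group at this position would follow compound 1 or compound 4 stays open.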